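Replacing 4-fluorophenyl in compound 2 with thiophen-2-yl

This account rests on a few compounds, and the source may have more. Where it says the series, first, only, none or still open, it means among the compounds named here.

In a functional assay on FM3A cells (Mus musculus) for antiproliferative activity (on this read-out lower numbers stand for stronger inhibition and higher numbers for weaker inhibition), compound 1 (`COc1cc(C(=O)c2sc(-c3ccc(Cl)c(Cl)c3)cc2N)cc(OC)c1OC`) gives 400 nM and compound 2 (`COc1cc(C(=O)c2sc(-c3ccc(F)cc3)cc2N)cc(OC)c1OC`) gives 16 nM, so compound 2 holds the lower of the two numbers. Compound 3 (`COc1cc(C(=O)c2sc(-c3cccs3)cc2N)cc(OC)c1OC`) has thiophen-2-yl in place of 4-fluorophenyl on an aromatic carbon, next to the ring sulfur: thiophen-2-yl in place of 4-fluorophenyl on an aromatic carbon. Among the compounds with values here, one measured step bears on this change: a 25-fold lower number from compound 1 to compound 2 (1.40 log units; beyond the scatter), a large step at the same place, with 4-fluorophenyl in place of 3,4-dichlorophenyl. Within the data shown here, it shows that the number can move widely with the group at this place, but no measured compound carries thiophen-2-yl. A modest rise in this assay, smaller than that step, is therefore expected, with the direction uncertain. The expected change is a 2.2-fold higher number from compound 2 to compound 3 (0.34 log units; beyond the scatter). Compound 3 is estimated at 35 nM, with an expected range of 10 nM to 150 nM.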

Compound 3, half-maximal inhibitory concentration: 1.7 nM
Estimate against measurement, compound 3: 21-fold (1.31 log units) above, outside the stated range (below it).
By their numbers in this assay, from the lowest: compound 3; then compound 2; then compound 1.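

In this assay the place next to the ring sulfur accepts a five-membered aromatic ring and not only a six-membered one: thiophen-2-yl in place of 4-fluorophenyl gives a 9.4-fold lower number from compound 2 to compound 3 (0.97 log units; beyond the scatter) and leaves compound 3 with the lowest number of the series. Against 3,4-dichlorophenyl the same group gives a 240-fold lower number from compound 1 to compound 3 (2.37 log units; beyond the scatter) as a large step, so the group at this place sets the number over a much wider span than the first pair showed, and the smaller aryl groups are not the limit of what fits here. No measurement at hand accounts for the size of either step.

Whether the gain belongs to thiophen-2-yl itself or to five-membered aromatic rings in general remains open, as furan-2-yl and thiophen-3-yl are not among the compounds shown. Also open, on these data alone, is how an aminomethyl or carboxylic acid group on the thiophene ring of compound 3 would move the number.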